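Dihydroxyphenyl for bromocyanophenyl on a naphthyloxyacetohydrazone

The source may hold more compounds than are shown below. What is called first, only, known or untested is meant among the compounds shown, and "the series" means these compounds.

The series shares a naphthyloxyacetohydrazide core. Compound 1 `C/C(=N\NC(=O)COc1cccc2ccccc12)c1ccc(C#N)cc1Br` carries a 2-bromo-4-cyanophenyl group on the carbon with a double bond to nitrogen, and in a physicochemical assay for lipophilicity, measured as octanol-water partition (a higher number here means a more lipophilic compound, a lower number a more polar compound), compound 1 gives 3.61. Compound 2 `O=C(COc1cccc2ccccc12)N/N=C/c1ccccc1Br` gives 4.81, and compound 3 `O=C(COc1cccc2ccccc12)N/N=C/c1ccc(Cl)cc1` gives 4.54. Compound 1 therefore stands lowest of the three, with compound 3 nearest and compound 2 furthest, both beyond the scatter. Among the compounds with values here, the one step measured between neighbours, a number 0.27 log units lower from compound 2 to compound 3 (within the scatter), tells only that swapping one halogenated phenyl for another changes little.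

Compound 4 `C/C(=N\NC(=O)COc1cccc2ccccc12)c1ccc(O)cc1O` differs from compound 1 in a single place: 2,4-dihydroxyphenyl in place of 2-bromo-4-cyanophenyl on a carbon with a double bond to nitrogen. Within the data shown here, no measured step covers a change of this kind, in which a bromine and a nitrile leave and two hydroxyl groups enter, so the expectation rests on the count of donors and acceptors given for the entering group rather than on a step seen in this set. On that basis the author expects a clear fall, a step of a number 1.21 log units lower from compound 1 to compound 4 (beyond the scatter) in this assay, well beyond the scatter. Compound 4 is accordingly estimated at 2.4, within a range of 1.6 to 3.2.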

Compound 4, partition coefficient: 4.31
For compound 4 the middle estimate is 1.91 log units below the measured one; the whole stated range lies below it.
By their numbers in this assay, from the lowest: compound 1; then compounds 4, 3 and 2 (each within the scatter of the next, the first and the last beyond it).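

The swap of 2-bromo-4-cyanophenyl for 2,4-dihydroxyphenyl gives, in this assay, a number 0.70 log units higher from compound 1 to compound 4 (beyond the scatter). This shows that a change on the carbon with a double bond to nitrogen can move this number by more than the scatter, which the earlier step, a number 0.27 log units lower from compound 2 to compound 3 (within the scatter), had not shown, and that here the entering group, with more hydrogen-bond donors and acceptors than the leaving one, goes with a higher number rather than a lower one. Nothing given here accounts for the direction or the size of this step.

The bromine and the nitrile leave and the two hydroxyl groups enter in one swap, so this single pair cannot separate what each of them contributes to the step. From the compounds shown here alone, how an amine or a carboxylic acid on the phenyl ring at this place would read in this assay also stays open, as does whether the direction seen between these two compounds would hold for any other pair.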